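A few compounds are considered here, and "the series" means these few. Any claim that something is new, unique, unknown or untested is made for them only; others in the source may bear on it.

Compound 2, `COc1ccc(NC(=O)[C@H]2CCCN2C(=O)C2(c3cccc(Cl)c3)CCCC2)nc1`, stands at the top of the three measured compounds in a physicochemical assay for lipophilicity, at pH 7.4 (a higher number here means a more lipophilic compound, a lower number a more polar compound), giving 6.8. The nearest of the others is compound 3, `O=C(Nc1ccc2[nH]ncc2n1)[C@H]1COCCN1C(=O)C1(c2ccc(Cl)cc2)CC(F)(F)C1`, which in this assay gives 4.5; the furthest is compound 1, `O=C(Nc1ccc2[nH]c(=O)[nH]c2c1)[C@H]1CCCN1C(=O)C1(c2cccc(Cl)c2)CCCC1`, which gives 4.4. Among the measured steps, only one changes a single group, and it leads straight into compound 2: it raised this assay by a number 2.40 log units higher from compound 1 to compound 2 (beyond the scatter) when the 5-methoxypyridin-2-yl replaced the larger bicyclic group on the amide-type nitrogen.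

Compound 4, `CNC(=O)c1ccc(NC(=O)[C@H]2CCCN2C(=O)C2(c3cccc(Cl)c3)CCCC2)cc1`, has not yet been measured. It differs from compound 2 at the same position: 4-(methylcarbamoyl)phenyl in place of 5-methoxypyridin-2-yl on an amide-type nitrogen. The entering group brings one hydrogen-bond donor where the leaving group had none, and that direction of change is the reverse of what accompanied the large rise from compound 1 to compound 2, so a fall rather than a rise is expected in this assay, though with one donor instead of two the step should be smaller than that one. The expected step from compound 2 to compound 4 is a number 1.40 log units lower from compound 2 to compound 4 (beyond the scatter). For compound 4 the estimated value is 5.4, with a range from 4.6 to 6.2.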

Compound 4, distribution coefficient: 5.3
For compound 4 the middle estimate is 0.10 log units above the measured one; the measured number falls inside the stated range.
By their numbers in this assay, from the lowest: compounds 1 and 3 (each within the scatter of the next); then compound 4; then compound 2.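

The position on the amide-type nitrogen now gives a large shift between two single-ring groups: 4-(methylcarbamoyl)phenyl in place of 5-methoxypyridin-2-yl gives a number 1.50 log units lower from compound 2 to compound 4 (beyond the scatter) in this assay, so a swing of this size at this place does not depend on the bicyclic group of compound 1. The same new compound also separates two groups of equal heavy-atom count, with a number 0.90 log units higher from compound 1 to compound 4 (beyond the scatter) in this assay, so the count of heavy atoms in the group on this nitrogen does not by itself set the number among these compounds. Nothing available explains either shift.

The step from 5-methoxypyridin-2-yl to 4-(methylcarbamoyl)phenyl changes the ring, the hydrogen-bond donors and the substituent all at once, so the compounds shown leave open which of these changes goes with the fall. As far as these compounds go, how an unsubstituted phenyl or a 4-(dimethylcarbamoyl)phenyl, which carries no amide hydrogen on its side chain, would stand on this nitrogen in this assay also remains open.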